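The source may report more compounds than this note shows. Statements on the series, on what has been measured and on what is new or still open speak of the compounds shown alone.

In a functional assay on HEK293 cells for activation of melanin-concentrating hormone receptor 1 (Rattus norvegicus), read by inositol phosphate accumulation (a lower number here means that less compound is needed, a higher number that more compound is needed for the effect), the three measured compounds give the following numbers: compound 1 `O=C(CCc1ccc(C(F)(F)F)cc1)Nc1ccc2nc(N3CCC(NS(=O)(=O)O)C3)ccc2c1` gives 50 nM; compound 2 `CC(C)N(C)c1ccc2cc(NC(=O)CCc3ccc(C(F)(F)F)cc3)ccc2n1` gives 140 nM; compound 3 `CC1CCN(c2ccc3cc(NC(=O)CCc4ccc(C(F)(F)F)cc4)ccc3n2)C1` gives 400 nM.

Compound 3 stands at the highest of the three numbers in this assay. Its nearest neighbour is compound 2, with a 2.9-fold higher number from compound 2 to compound 3 (0.46 log units; beyond the scatter), and the furthest is compound 1, with an 8.0-fold higher number from compound 1 to compound 3 (0.90 log units; beyond the scatter).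

Compound 4 `O=C(CCc1ccc(C(F)(F)F)cc1)Nc1ccc2nc(N3CC4CCC3CC4)ccc2c1` differs from compound 3 in one place: a group of 8 heavy atoms (7 carbon, 1 nitrogen; 2 six-membered non-aromatic rings with 1 hetero atom each) in place of a group of 6 heavy atoms (5 carbon, 1 nitrogen; one five-membered non-aromatic ring with 1 hetero atom), on an aromatic carbon. For the measured compounds named here, no measured step covers this particular exchange. Going by the values given here, the two steps that alter the amine substituent on that aromatic carbon are a 2.8-fold higher number from compound 1 to compound 2 (0.45 log units; beyond the scatter) and a 2.9-fold higher number from compound 2 to compound 3 (0.46 log units; beyond the scatter), both modest; the one step that changes a group inside the saturated ring, an 8.0-fold higher number from compound 1 to compound 3 (0.90 log units; beyond the scatter), is larger. All three substituents at this position that lack the sulfoamino group lie within a modest span of each other, so the replacement of one small saturated amine by another is expected to shift the number in this assay only modestly, in either direction, and quite possibly not beyond the scatter, giving no change at the digits printed from compound 3 to compound 4 (within the scatter).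

On that basis compound 4 is expected to give about 400 nM in this assay, with a likely range from 130 nM to 1300 nM.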

Compound 4, half-maximal effective concentration: 190 nM
Compound 4: middle estimate off by 2.1-fold (0.32 log units), on the high side, and the stated range covers the measured number.
By their numbers in this assay, from the lowest: compound 1; then compounds 2 and 4 (each within the scatter of the next); then compound 3.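

In this assay, the exchange of 3-methylpyrrolidin-1-yl for the group with two six-membered non-aromatic rings gives a 2.1-fold lower number from compound 3 to compound 4 (0.32 log units; beyond the scatter), showing that this position on the aromatic carbon next to the ring nitrogen tolerates a larger saturated amine without a rise in the number. Compared with the open-chain isopropyl(methyl)amino group, the same ring group gives a 1.4-fold higher number from compound 2 to compound 4 (0.13 log units; within the scatter), so these two amines cannot be told apart here, and among compounds 2, 3 and 4 the number does not follow the size of the group, with the mid-sized group of compound 3 giving the highest number. The sulfoamino-bearing group keeps its place at the low end, with a 3.8-fold higher number from compound 1 to compound 4 (0.58 log units; beyond the scatter), and compound 1 remains beyond the scatter of each of the other three.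

Nothing available explains why the ring group of compound 4 and the 3-methylpyrrolidin-1-yl group differ in this way. On these data alone, it remains open whether a carboxylic acid or a primary amine on the pyrrolidine ring would match the sulfoamino group of compound 1, and how a morpholine or an unbridged piperidine would compare at this aromatic carbon.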